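Shifting the Hydroxyl on the Amide Aryl Ring

The compounds below may be only part of what the source reports. "The series", "measured", "known", "first", "only" and "open" are said of these compounds alone.

Among the compounds with values here, compound 2 `O=C(Nc1ccc(O)cc1)c1cc2cc(Cl)cc(Br)c2oc1=O` gives 41000 nM in an assay on isolated protein for inhibition of coagulation factor XII (Homo sapiens), read by HPLC, with stated times of 10 min and 30 min (on this read-out higher numbers stand for weaker inhibition and lower numbers for stronger inhibition), the highest of the two numbers measured so far; its nearest neighbour is compound 1 `O=C(Nc1cc(Cl)ccc1O)c1cc2cc(Cl)cc(Br)c2oc1=O`, which in this assay gives 5000 nM. Within the data shown here, the only measured step, an 8.2-fold higher number from compound 1 to compound 2 (0.91 log units; beyond the scatter), altered two groups at once, so it bears only loosely on the move to compound 3 `O=C(Nc1cccc(O)c1)c1cc2cc(Cl)cc(Br)c2oc1=O`, which differs from compound 2 by 3-hydroxyphenyl in place of 4-hydroxyphenyl on an amide-type nitrogen. Among the measured compounds shown here, with no directly comparable step, only a small to modest change is expected, in either direction. Compound 3 is therefore estimated at 25000 nM, within 8000 nM to 80000 nM, an expected step of a 1.6-fold lower number from compound 2 to compound 3 (0.21 log units; within the scatter).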

Compound 3, half-maximal inhibitory concentration in the coagulation factor XII assay: 34000 nM
For compound 3 the middle estimate is 1.4-fold (0.13 log units) below the measured one; the range from low to high includes it.
By their numbers in the coagulation factor XII assay, from the lowest: compound 1; then compounds 3 and 2 (each within the scatter of the next).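

In the coagulation factor XII assay swapping 4-hydroxyphenyl for 3-hydroxyphenyl on the amide-type nitrogen gives a 1.2-fold lower number from compound 2 to compound 3 (0.08 log units; within the scatter) and in a physicochemical assay for solubility, at pH 6.5 (a higher number here means a more soluble compound, a lower number a less soluble compound), it gives a 1.1-fold lower number from compound 2 to compound 3 (0.03 log units; within the scatter) with compound 2 at 1.5 ug/mL and compound 3 at 1.4 ug/mL and so neither read-out separates these two groups. Compound 1 also stands apart from compound 3: the coagulation factor XII assay shows a 6.8-fold higher number from compound 1 to compound 3 (0.83 log units; beyond the scatter) and so the gap does not belong to the 4-hydroxyphenyl group alone. No measurement here gives a reason for either result.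

As far as these compounds go, whether the chlorine or the hydroxyl placement in compound 1 carries that gap stays open, as does the outcome with an amine or a carboxylic acid in place of the hydroxyl.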